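This account rests on a few compounds, and the source may have more. Where it says the series, first, only, none or still open, it means among the compounds named here.

Measured compounds:
compound 1 `Cc1cccc(N2CCN(CC(=O)N(c3ccccc3)c3ccccc3)CC2)c1C` — > 30 mg/kg
compound 2 `O=C(CN1CCN(c2ccc(F)cc2)CC1)N(c1ccccc1)c1ccccc1` — 20 mg/kg

In a functional assay on the whole organism (strain Swiss albino) for inhibition, with Mus musculus as the target, with stated times of 30 min, 10 min and 20 min (a higher number here means that more compound is needed for the effect, a lower number that less compound is needed), compound 1 is recorded only as a limit of the assay, > 30 mg/kg, not as a number. For the measured compounds named here, compound 2 gives 20 mg/kg in this assay and holds the only number. Going by the values given here, the single measured step is an at least 1.5-fold lower number from compound 1 to compound 2 (0.17 log units; that floor lies within the scatter), and its floor sits within the scatter, so the exchange of the aryl group on the amine nitrogen in the ring gave no change that can be called real. Compound 3 `O=C(CN1CCN(c2ccc([N+](=O)[O-])cc2)CC1)N(c1ccccc1)c1ccccc1` carries nitro in place of fluoro on an aromatic carbon. The measured step bears on it only in that it also exchanges the aryl group; it shows no step beyond the scatter for such an exchange. For compound 3 in this assay no step beyond the scatter is therefore expected. Compound 3 is estimated at 20 mg/kg, between 8 mg/kg and 50 mg/kg. This corresponds to an expected step of no change at the digits printed from compound 2 to compound 3 (within the scatter).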

Compound 3, dose for half-maximal effect: > 40 mg/kg
Compound 3: only a limit was reported; the forecaster's own chance of this, stated with the estimate: 30%; middle value at least 2.0-fold (0.30 log units) from the limit.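

In this assay, for the compounds shown here, the exchange at the aromatic carbon para to a large group, nitro in place of fluoro, gives an at least 2.0-fold higher number from compound 2 to compound 3 (0.30 log units; that floor lies within the scatter), so this first change confined to that substituent shows no step that can be called real. Going by these compounds alone, the value of compound 3 is a limit and not a number: the limit of > 40 mg/kg in this assay, at which 1 of the 3 values shown sits. The step from compound 1 to compound 3 cannot be read, and compound 2 remains the only compound with a number.

From the compounds shown here alone, it remains open how far the value of compound 3 lies from that of compound 2. Also open, going by these compounds, is how an amine, a carboxylic acid or a methoxy group on this aromatic carbon would read in this assay, and whether any group here gives a step beyond the scatter.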